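Aryl swap on the triazole nitrogen: outlook for compound 3

A few compounds are considered here, and "the series" means these few. Any claim that something is new, unique, unknown or untested is made for them only; others in the source may bear on it.

Measured compounds:
compound 1 `CCOc1ccc(-n2nncc2CN2C(=O)C3(C(C#N)=C(N)Oc4c3c3nc5ccccc5nc3c3ccccc43)c3ccccc32)cc1` — > 50000 nM
compound 2 `N#CC1=C(N)Oc2c(c3nc4ccccc4nc3c3ccccc23)C12C(=O)N(Cc1cnnn1-c1ccc(S(N)(=O)=O)cc1)c1ccccc12` — > 50000 nM

In an ADME assay on L02 cells (Homo sapiens) for antiproliferative activity, read by MTT assay, with a stated time of 48 h (a lower number here means a stronger inhibitor, a higher number a weaker inhibitor), compound 1 gives > 50000 nM, which is a limit of the assay and not a number. Compound 2 likewise gives > 50000 nM, also a limit. Both values sit at the limit of > 50000 nM in this assay, at which 2 of the 2 values shown sit. The step that the two limits leave unreadable from compound 1 to compound 2 is therefore of unreadable size. Going by the values given here, compound 1 thus stands only at a limit, and the one further value shown is a limit as well.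

Compound 3 `N#CC1=C(N)Oc2c(c3nc4ccccc4nc3c3ccccc23)C12C(=O)N(Cc1cnnn1-c1ccc(Cl)c(Cl)c1)c1ccccc12` differs from compound 1 by 3,4-dichlorophenyl in place of 4-ethoxyphenyl on an aromatic nitrogen. Among the compounds with values here, the only measured step bearing on it, an exchange of the aryl group at the same place, gives no readable size, so it supports no expectation of a change beyond the scatter in either direction. Compound 3 is expected to give 60000 nM (estimated range 20000 nM to 200000 nM), most probably reported again only as a limit. The expected step that the limit leaves unreadable from compound 1 to compound 3 is thus essentially none.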

Compound 3, half-maximal inhibitory concentration: > 50000 nM
Compound 3 ended at the assay's limit; the forecaster's own chance of this, stated with the estimate: 75%; the middle value lies beyond the limit too.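

In this assay the steps from compound 1 to compound 3 and from compound 2 to compound 3 cannot be read, because all three compounds stand at a limit and not at a number: the limit of > 50000 nM in this assay, at which 3 of the 3 values shown sit.

On these data alone, whether any aryl group on this aromatic nitrogen gives a readable value in this assay stays open.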